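Fluoro on the central ring of compound 1

A few compounds are considered here, and "the series" means these few. Any claim that something is new, unique, unknown or untested is made for them only; others in the source may bear on it.

Compound 1 `O=C(Nc1ccc(Oc2ccnc3[nH]ccc23)cc1)c1cc2cccnc2n(-c2ccc(F)c(Cl)c2)c1=O` is the reference point of this pair. In a functional assay on A549 cells (Homo sapiens) for antiproliferative activity, read by MTT assay, with a stated time of 72 h (a lower number here means a stronger inhibitor, a higher number a weaker inhibitor), compound 1 gives 680 nM, the lowest of the two numbers obtained so far. Going by the values given here, compound 2 `O=C(Nc1ccc(Oc2ccnc3[nH]ccc23)cc1)c1cc2cccnc2n(-c2ccc(C(F)(F)F)cc2Cl)c1=O` carries a different aryl group on the aromatic nitrogen of the shared core; in this assay compound 2 gives 3230 nM, and the step of a 4.8-fold higher number from compound 1 to compound 2 (0.68 log units; beyond the scatter) is the only measured step.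

Compound 3 `O=C(Nc1ccc(Oc2ccnc3[nH]ccc23)c(F)c1)c1cc2cccnc2n(-c2ccc(F)c(Cl)c2)c1=O` is the next member to be tested. It differs from compound 1 by fluoro in place of hydrogen on an aromatic carbon. The aryl group on the aromatic nitrogen is left as in compound 1. Among the compounds with values here, the one measured step concerns that aryl group only and so does not bear on this change; nothing measured here speaks to adding fluoro on the central phenyl ring. Within the data shown here, with no relevant step, the expectation is a change that stays within the scatter, written as a 1.2-fold lower number from compound 1 to compound 3 (0.09 log units; within the scatter). Compound 3 is therefore estimated to give 550 nM in this assay, with a range from 200 nM to 1600 nM to allow for the unknown.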

Compound 3, half-maximal inhibitory concentration: 630 nM
The estimate for compound 3 lay 1.1-fold (0.06 log units) below the measured number; the measured number falls inside the stated range.
By their numbers in this assay, from the lowest: compounds 3 and 1 (each within the scatter of the next); then compound 2.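

In this assay the step from hydrogen to fluoro on this six-membered aromatic ring of carbon only reads as a 1.1-fold lower number from compound 1 to compound 3 (0.03 log units; within the scatter) and so lies within the scatter, which means that this single fluorine, ortho to a large group and meta to a large group, leaves the number where it was. Going by these compounds alone, this is the first reading on this ring, since the earlier step, a 4.8-fold higher number from compound 1 to compound 2 (0.68 log units; beyond the scatter), lies beyond the scatter but concerns only the aryl group on the aromatic nitrogen, so the series now holds one change that moves the number and one that does not. No measurement available here accounts for this result.

The compounds shown leave open whether anything larger than fluoro at this same carbon, such as chloro, methoxy, an amine or a carboxylic acid, would also leave the number unchanged, and whether the other carbons of this ring accept a substituent equally well. They also leave open whether fluoro at this carbon gives the same result alongside the 2-chloro-4-(trifluoromethyl)phenyl group of compound 2.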